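The compounds below may be only part of what the source reports. "The series", "measured", "known", "first", "only" and "open" are said of these compounds alone.

Measured so far, in a physicochemical assay for lipophilicity, at pH 7.4; on this read-out lower numbers stand for lower lipophilicity and higher numbers for higher lipophilicity:

- compound 1 `CCc1ccc(N(C2CCC2)S(=O)(=O)c2ccc3c(c2)C(O)CC(C2CCOCC2)O3)cc1` gives 3.69
- compound 2 `CCc1ccc(N(CC(C)C)S(=O)(=O)c2ccc3c(c2)C(O)CC(C2CCOCC2)O3)cc1` gives 4.12
- compound 3 `CCc1ccc(N(CC(C)C)S(=O)(=O)c2ccc3c(c2)C(O)C[C@@H](C2CCOCC2)O3)cc1` gives 4.12

Compound 2 stands level with compound 3 at the digits shown, and the two together hold the highest of the three numbers; compound 1 sits furthest from compound 2. Two measured steps connect these compounds. The first is a number 0.43 log units higher from compound 1 to compound 2 (beyond the scatter). The second is no change at the digits printed from compound 2 to compound 3 (within the scatter), which is consistent with the fact that one of compounds 2 and 3 is drawn with a defined configuration and the other without, at the place where they differ.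

Compound 4 `CC(C)CN(c1ccc(F)cc1F)S(=O)(=O)c1ccc2c(c1)C(O)CC(C1CCOCC1)O2` has not yet been measured in this assay. It differs from compound 2 in one place: 2,4-difluorophenyl in place of 4-ethylphenyl on a sulfonamide nitrogen. Neither measured step bears on this part of the molecule, since both keep the 4-ethylphenyl on the sulfonamide nitrogen, so they give no direct guide to the size or direction of the coming step, and the expectation that follows rests only on the value of compound 2, 4.12, as a starting point. The step from compound 2 to compound 4 in this assay is expected to be a number 0.32 log units lower from compound 2 to compound 4 (beyond the scatter). Compound 4 is therefore estimated at 3.8, with a range from 3.3 to 4.3.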

Compound 4, distribution coefficient: 3.53
Beside the measured number, compound 4's estimate is 0.27 log units above it; measured number inside the range.
By their numbers in this assay, from the lowest: compounds 4 and 1 (each within the scatter of the next); then compounds 2 and 3 (each within the scatter of the next).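

The ring on the sulfonamide nitrogen proves to be a place where this assay responds: 2,4-difluorophenyl in place of 4-ethylphenyl gives a number 0.59 log units lower from compound 2 to compound 4 (beyond the scatter) on the isobutyl series. Going by these compounds alone, the earlier steps all kept the 4-ethylphenyl, changing only the other group on that nitrogen or how a stereocentre is drawn, so this is the first view of what a change to this ring does. Nothing at hand explains the step.

This one change removes the ethyl group and brings in two fluorines together, so the compounds shown cannot say how much of the step belongs to each; a plain phenyl ring on the same nitrogen would help to separate them. On these data alone, whether a step of similar size would appear with the cyclobutyl of compound 1 on that nitrogen also stays open.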